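The source may report more compounds than this note shows. Statements on the series, on what has been measured and on what is new or still open speak of the compounds shown alone.

For the measured compounds named here, compound 1 `O=C(O)c1cc(F)c(F)c(F)c1O` stands lowest of the two numbers known in a toxicity assay on the whole organism (strain CD-1) for cytotoxicity, with Mus musculus as the target, with a stated time of 14 days, at a dose of 300 mg/kg by the intraperitoneal route (a lower number here means a stronger effect, a higher number a weaker effect of the compound at the dose given), at 0%; compound 2 `O=C(O)c1ccc(F)c(F)c1O` gives 33%, the only neighbour. Going by the values given here, the one measured step, a number 33 percentage points higher from compound 1 to compound 2 (beyond the scatter), came from the change hydrogen in place of fluoro on an aromatic carbon. Compound 3 `O=C(O)c1cc(F)c(F)cc1O` differs from compound 1 by hydrogen in place of fluoro on an aromatic carbon, the same kind of change at another place. That step is therefore expected to carry over, giving a rise of about a number 25 percentage points higher from compound 1 to compound 3 (beyond the scatter) in this assay. Compound 3 is thus estimated at 25%, within 0% to 55%.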

Compound 3, a percentage reported as activity, at one dose (the size of the read-out at that dose, not a potency): 33%
Compound 3: the middle estimate sits 8 percentage points below what was measured; the range from low to high includes it.
By their numbers in this assay, from the lowest: compound 1; then compounds 2 and 3 (each within the scatter of the next).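

Losing the fluoro that sits ortho to a hydroxy group and meta to a carboxy group gives a number 33 percentage points higher from compound 1 to compound 3 (beyond the scatter) in this assay and so counts as a large step at this position too. The same kind of change at the other place gave a number 33 percentage points higher from compound 1 to compound 2 (beyond the scatter) in the same assay, so the rise is seen at both places tested. No evidence at hand accounts for either step.

The compounds shown leave open what a chloro group or a methoxy group would do at this position. They also leave open how a core carrying an amine in place of the carboxylic acid would behave.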